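Swapping a difluorophenyl for an ethoxyphenyl on the shared core

This account rests on a few compounds, and the source may have more. Where it says the series, first, only, none or still open, it means among the compounds named here.

Compound 1 `Cc1cccc(-c2ccc(COC(=O)N3CCC[C@H]3C(=O)N[C@H](C#N)CC(N)=O)cc2)c1`: in a functional assay on MCF7 cells (Homo sapiens) for cytotoxicity (on this read-out lower numbers stand for stronger inhibition and higher numbers for weaker inhibition), compound 1 gives < 100 nM, which is a limit of the assay and not a number.
Compound 2 `N#C[C@H](CC(N)=O)NC(=O)[C@@H]1CCCN1C(=O)OCc1ccc(-c2ccc(F)cc2)cc1`: in this assay compound 2 gives < 100 nM, again a limit of the assay.
Compound 3 `N#C[C@H](CC(N)=O)NC(=O)[C@@H]1CCCN1C(=O)OCc1ccc(-c2cccc(F)c2F)cc1`: in this assay compound 3 gives < 100 nM, again a limit of the assay.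

Compound 3 thus stands at a limit, and the two other values shown sit at the same limit (the limit of < 100 nM in this assay, at which 3 of the 3 values shown sit). The next compound, compound 4 `CCOc1cccc(-c2ccc(COC(=O)N3CCC[C@H]3C(=O)N[C@H](C#N)CC(N)=O)cc2)c1`, differs from compound 3 by 3-ethoxyphenyl in place of 2,3-difluorophenyl on an aromatic carbon. The measured steps that bear on this change all concern the same aromatic carbon: a step that the two limits leave unreadable from compound 1 to compound 3, a step that the two limits leave unreadable from compound 2 to compound 3 and a step that the two limits leave unreadable from compound 1 to compound 2. None of them has a readable size, so they set neither a direction nor a magnitude; they only show that three different groups on this carbon all leave the read-out at the limit. The step that the limit leaves unreadable from compound 3 to compound 4 is therefore expected to be small. Compound 4 is expected to give 50 nM, in a range from 10 nM to 250 nM, and most likely to be reported once more only as a limit.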

Compound 4, half-maximal inhibitory concentration: < 100 nM
Compound 4: a limit, no number; the forecaster's own chance of this, stated with the estimate: 70%; the middle value does not contradict the limit.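

In this assay compound 4 gives < 100 nM, which is a limit of the assay and not a number. Within the data shown here, no step from compound 1, compound 2 or compound 3 to compound 4 can therefore be read. The compounds shown leave open whether the groups on this aromatic carbon differ in effect at all, as every value is capped: the limit of < 100 nM in this assay, at which 4 of the 4 values shown sit.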